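Cytotoxicity series: amine substituent variation on a shared core

The source may report more compounds than this note shows. Statements on the series, on what has been measured and on what is new or still open speak of the compounds shown alone.

Compound 1 `C#CCNCC(O)COc1ccc2c(C)c(Cc3ccccc3)c(=O)oc2c1`: in an ADME assay on A549 cells (Homo sapiens) for cytotoxicity, read by CellTiter-Glo (on this read-out higher numbers stand for lower toxicity in this test and lower numbers for higher toxicity in this test), compound 1 gives 95500 nM.
Compound 2 `Cc1c(Cc2ccccc2)c(=O)oc2cc(OCC(O)CNc3ccc(Br)cc3)ccc12`: compound 2 gives > 100000 nM in this assay, which is a limit of the assay, not a number.
Compound 3 `Cc1c(Cc2ccccc2)c(=O)oc2cc(OCC(O)CNCc3ccccc3)ccc12`: compound 3 gives > 100000 nM in this assay, again a limit of the assay.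

Compound 3 therefore stands only at a limit, sitting at the limit of > 100000 nM in this assay, at which 2 of the 3 values shown sit. Compound 4 `Cc1c(Cc2ccccc2)c(=O)oc2cc(OCC(O)CNCCCCCCO)ccc12` differs from compound 3 by 5-hydroxypentyl in place of phenyl on a saturated chain carbon bound to an amine nitrogen. The measured steps that touch this same position are an at least 1.0-fold higher number from compound 1 to compound 3 (0.01 log units; that floor lies within the scatter) and a step that the two limits leave unreadable from compound 2 to compound 3, and alongside them an at least 1.0-fold higher number from compound 1 to compound 2 (0.01 log units; that floor lies within the scatter); none of the three is readable as a change beyond the scatter. For the change to compound 4 no step beyond the scatter is expected, so the expected step is a number no higher from compound 3 to compound 4 (the limit leaves the size open). Compound 4 is expected to give about 100000 nM in this assay, within 60000 nM to 300000 nM, with a limit again the likeliest report.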

Compound 4, half-maximal cytotoxic concentration: 40300 nM
Compound 4: the middle estimate sits 2.5-fold (0.39 log units) above what was measured; the measured number lies below the stated range.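

In this assay, within the data shown here, this position now moves the read-out beyond the scatter: 5-hydroxypentyl in place of phenyl gives an at least 2.4-fold lower number from compound 3 to compound 4 (0.39 log units; beyond the scatter), and 6-hydroxyhexyl in place of 4-bromophenyl gives an at least 2.4-fold lower number from compound 2 to compound 4 (0.39 log units; beyond the scatter). 5-hydroxypentyl in place of ethynyl gives a 2.4-fold lower number from compound 1 to compound 4 (0.37 log units; beyond the scatter), the only one of these steps with a full size rather than a floor. The other two steps are floors: the limit of > 100000 nM in this assay, at which 2 of the 4 values shown sit.

On these data alone, whether the step belongs to the hydroxyl of the 6-hydroxyhexyl group or to the open chain itself stays open. An unsubstituted hexyl group or a longer chain would bear on this.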